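Swapping a methyl for phenoxy on a sulfonamide aryl ring

This account rests on a few compounds, and the source may have more. Where it says the series, first, only, none or still open, it means among the compounds named here.

Compound 1 `Cc1ccc(NS(=O)(=O)c2cccc(CCCCCCNC(=O)/C=C/c3cccnc3)c2)cc1` gives 1.97 nM
Compound 2 `O=C(/C=C/c1cccnc1)NCCCCCCc1cccc(S(=O)(=O)Nc2ccc(F)c(Cl)c2)c1` gives 6.3 nM

In a functional assay on MCF7 cells (Homo sapiens) for inhibition, read by CCK-8 assay, with a stated time of 72 h (on this read-out higher numbers stand for weaker inhibition and lower numbers for stronger inhibition), compound 1 holds the lower of the two numbers at 1.97 nM, which makes it the stronger inhibitor of this pair. Compound 3 `O=C(/C=C/c1cccnc1)NCCCCCCc1cccc(S(=O)(=O)Nc2ccc(Oc3ccccc3)cc2)c1` has not yet been measured. It keeps the core of compound 1 and changes one group: phenoxy in place of methyl on an aromatic carbon. In words, this is phenoxy in place of methyl on an aromatic carbon, para to a large group.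

For the measured compounds named here, only one measured step bears on this change. That step, a 3.2-fold higher number from compound 1 to compound 2 (0.50 log units; beyond the scatter), is modest but beyond the scatter, and it also replaces the methyl-bearing ring substituent on the sulfonamide nitrogen. A single step is thin evidence, and nothing measured here carries a phenoxy group. A modest move towards a higher number, meaning weaker inhibition, is therefore the most reasonable expectation. The expected change is a 2.5-fold higher number from compound 1 to compound 3 (0.40 log units; beyond the scatter), and this is an estimate only. Compound 3 is expected to give about 5 nM, with an estimated range of 1 nM to 25 nM.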

Compound 3, half-maximal inhibitory concentration: 3.84 nM
Estimate against measurement, compound 3: 1.3-fold (0.11 log units) above; measured number inside the range.
By their numbers in this assay, from the lowest: compounds 1, 3 and 2 (each within the scatter of the next, the first and the last beyond it).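

The step to the larger group reads, in this assay, as a 1.9-fold higher number from compound 1 to compound 3 (0.29 log units; within the scatter) and so gives no separation between the two compounds, even though 7 heavy atoms and a six-membered aromatic ring now stand where 1 methyl carbon stood. For the compounds shown here, the earlier step, a 3.2-fold higher number from compound 1 to compound 2 (0.50 log units; beyond the scatter) on the same read-out, showed only that a different ring on the sulfonamide nitrogen could shift the number beyond the scatter, whereas this result shows that the place para to a large group can carry a far bigger phenoxy substituent with the number staying within the scatter of the methyl compound. Nothing measured here accounts for this result.

Going by these compounds, whether the place would accept a group of another kind, such as an amine or a carboxylic acid in place of phenoxy, remains open, since both groups compared here are joined to the ring through carbon or an ether oxygen and neither carries nitrogen. On these data alone, it is also open whether a still larger group, such as benzyloxy, would keep the number within the scatter or whether phenoxy already lies near the limit of what this place can hold.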